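Methoxy removal on the dimethoxyphenyl piperazine series

This account rests on a few compounds, and the source may have more. Where it says the series, first, only, none or still open, it means among the compounds named here.

The shared core carries an aryl piperazine amide; compound 3 `COc1cc(OC)cc(N2CCN(C(=O)c3oc(C)nc3-c3ccccc3)CC2)c1` gives 19.2 nM in a functional assay on HL-60 cells (Homo sapiens) for inhibition, read by MTT assay, with a stated time of 72 h (on this read-out lower numbers stand for stronger inhibition and higher numbers for weaker inhibition), and compound 2 `COc1cc(OC)cc(N2CCN(C(=O)c3oc(C)nc3-c3cccc(F)c3)CC2)c1` gives 28.2 nM in this assay. The two cores differ by fluoro in place of hydrogen on an aromatic carbon, and the corresponding step is a 1.5-fold lower number from compound 2 to compound 3 (0.17 log units; within the scatter). Compound 1 `COc1cccc(N2CCN(C(=O)c3oc(C)nc3-c3ccccc3)CC2)c1` gives 34.8 nM in this assay. From compound 3 to compound 1 the change is hydrogen in place of methoxy on an aromatic carbon, and it made a step of a 1.8-fold higher number from compound 3 to compound 1 (0.26 log units; within the scatter). Compound 4 `COc1cccc(N2CCN(C(=O)c3oc(C)nc3-c3cccc(F)c3)CC2)c1` has not yet been measured in this assay. Within the data shown here, it differs from compound 2 by hydrogen in place of methoxy on an aromatic carbon, which is the same change as the one from compound 3 to compound 1, at the same kind of place on the same kind of ring. The expected step from compound 2 to compound 4 is a 1.8-fold higher number from compound 2 to compound 4 (0.25 log units; within the scatter), set beside the earlier one, because a 1.8-fold higher number from compound 3 to compound 1 (0.26 log units; within the scatter) is the only direct record of this change in the set; a second route through compound 1, with 34.8 nM, and the fluoro step a 1.5-fold lower number from compound 2 to compound 3 (0.17 log units; within the scatter) points the same way. Compound 4 is therefore estimated at 50 nM, with an expected span from 25 nM to 100 nM.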

Compound 4, half-maximal inhibitory concentration: "not active" (no number reported)
For compound 4 the study gives words and no number; there is nothing to compare the estimate with.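

Among these compounds, compound 4 is reported in this assay as "not active", in words only, so no step from compound 2 or compound 1 to compound 4 can be read. Nothing shown bears on this result. The compounds shown leave open how far compound 4 stands from compound 2 on a numerical scale.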